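Switching the Double-Bond Geometry of an Oxindole Benzylidene

A few compounds are considered here, and "the series" means these few. Any claim that something is new, unique, unknown or untested is made for them only; others in the source may bear on it.

Measured compounds:
compound 1 `COc1cc(Cn2cc(COc3cccc(/C=C4\C(=O)Nc5ccccc54)c3)nn2)cc(OC)c1`: 33800 nM
compound 2 `O=C1Nc2ccc([N+](=O)[O-])cc2/C1=C\c1cccc(OCc2cn(Cc3ccccc3)nn2)c1`: > 50000 nM
compound 3 `O=C1Nc2ccc(C(c3ccccc3)c3ccccc3)cc2/C1=C\c1cccc(OCc2cn(Cc3ccccc3)nn2)c1`: > 50000 nM

In a functional assay on HeLa cells (Homo sapiens) for inhibition, read by MTT assay, with a stated time of 48 h (a higher number here means a weaker inhibitor, a lower number a stronger inhibitor), compound 1 gives 33800 nM. For compound 2 this assay reports only a limit, > 50000 nM. For compound 3 this assay likewise returns a limit, > 50000 nM, so compound 3 stands at the edge of what this assay can record, together with compound 2 (the limit of > 50000 nM in this assay, at which 2 of the 3 values shown sit). Compound 1 is the only one of the three with a numerical value, and that number itself sits high.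

Compound 4 `O=C1Nc2ccc(C(c3ccccc3)c3ccccc3)cc2/C1=C/c1cccc(OCc2cn(Cc3ccccc3)nn2)c1` is the next compound. Compared with compound 3, (the two compounds have the same atoms and bonds and differ only in configuration as drawn: 1 of 1 stereo elements differ; a double bond is drawn E in compound 3 and Z in compound 4). Nothing else changes; the same atoms and bonds are present in both.

For the measured compounds named here, no measured pair in this set shares this kind of change, so there is no measured step to lean on. Since compound 3 gives only a limit, the step to compound 4 cannot be predicted in size or direction from the data at hand. Compound 4 is therefore expected to land near the weak end, with the estimated step of an at least 1.6-fold lower number from compound 3 to compound 4 (0.22 log units; that floor lies within the scatter) carrying wide uncertainty. Compound 4 is estimated at 30000 nM, in a range from 6000 nM to 80000 nM.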

Compound 4, half-maximal inhibitory concentration: 4280 nM
For compound 4 the middle estimate is 7.0-fold (0.85 log units) above the measured one; measured number below the stated range.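

For the compounds shown here, compound 3 and compound 4 give the first comparison in this set in which only the geometry of the double bond changes, and in this assay that change alone produces a large step (an at least 11-fold lower number from compound 3 to compound 4 (1.06 log units; beyond the scatter)) . No atom enters or leaves, so the whole difference rests on configuration: the fact that compounds 3 and 4 differ only in the configuration as drawn. The earlier compounds shown here offered no such comparison, and the step has only a floor, with compound 3 among the compounds held at the edge of the read-out: the limit of > 50000 nM in this assay, at which 2 of the 4 values shown sit.

Going by these compounds, it remains open whether the same change of geometry gives a step of like size on compound 2, with its nitro group. Also open, on these data alone, is how an amine or a carboxylic acid in place of the diphenylmethyl group would fare with the double bond as drawn in compound 4.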